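The compounds below may be only part of what the source reports. "The series", "measured", "known", "first", "only" and "open" are said of these compounds alone.

Among the measured compounds shown here, in an ADME assay on J774.1 cells (Mus musculus) for cytotoxicity, read by resazurin assay, with a stated time of 48 h (on this read-out higher numbers stand for weaker inhibition and lower numbers for stronger inhibition), compound 1 `CCCCn1cc(C(=O)NCc2ccccc2)c(=O)c2cc(F)c(N3CCC(C(N)=O)CC3)cc21` gives 47000 nM and compound 2 `CCCCn1cc(C(=O)NCc2ccccc2)c(=O)c2cc(F)c(N(C)Cc3ccccc3)cc21` gives 86000 nM, so compound 2 stands within the scatter of the only other measured number. Compound 3 `CCCCn1cc(C(=O)NCc2ccccc2)c(=O)c2cc(F)c(N3CCCCC3)cc21` has piperidin-1-yl in place of benzyl(methyl)amino on an aromatic carbon. For the measured compounds named here, the one measured step bearing on this exchange, a 1.8-fold higher number from compound 1 to compound 2 (0.26 log units; within the scatter), swaps 4-carbamoylpiperidin-1-yl and benzyl(methyl)amino on that same carbon, so no step beyond the scatter is expected in this assay. The expected step is a 1.4-fold lower number from compound 2 to compound 3 (0.16 log units; within the scatter). For compound 3 the estimate is 60000 nM, with an expected range from 25000 nM to 130000 nM.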

Compound 3, half-maximal inhibitory concentration: 47800 nM
Compound 3: the middle estimate sits 1.3-fold (0.10 log units) above what was measured; the measured number falls inside the stated range.
By their numbers in this assay, from the lowest: compounds 1, 3 and 2 (each within the scatter of the next).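

In this assay there is a 1.8-fold lower number from compound 2 to compound 3 (0.26 log units; within the scatter) when piperidin-1-yl enters for benzyl(methyl)amino, so this aromatic carbon, ortho to a fluoro group, tolerates the loss of the six-membered aromatic ring of carbon only without a step beyond the scatter. There is likewise a 1.0-fold higher number from compound 1 to compound 3 (0.01 log units; within the scatter) when hydrogen replaces carbamoyl on the saturated ring carbon, so that group makes no difference beyond the scatter here. No measured evidence accounts for either result. Going by these compounds, whether a piperazine ring or a carboxylic acid on the saturated ring would move the number beyond the scatter stays open.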